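Methylsulfanyl to methylamino: compound 3 to compound 4

The source may report more compounds than this note shows. Statements on the series, on what has been measured and on what is new or still open speak of the compounds shown alone.

In a functional assay on K562 cells (Homo sapiens), read by MTT assay, with a stated time of 72 h (a lower number here means a stronger inhibitor, a higher number a weaker inhibitor), compound 1 (`COc1ncnc2c1c(-c1ccccc1)cn2[C@@H]1O[C@H](CO)[C@@H](O)[C@H]1O`) gives > 20000 nM, which is a limit and not a number. That leaves (the limit of > 20000 nM in this assay, at which 1 of the 3 values shown sits). Compound 2 (`COc1ncnc2c1c(-c1cc3ccccc3o1)cn2[C@@H]1O[C@H](CO)[C@@H](O)[C@H]1O`) gives 20900 nM. Compound 3 (`CSc1ncnc2c1c(-c1ccsc1)cn2[C@@H]1O[C@H](CO)[C@@H](O)[C@H]1O`) gives 450 nM, the lower of the two true numbers and beyond the scatter from compound 2, its nearest neighbour.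

The next structure is compound 4 (`CNc1ncnc2c1c(-c1ccsc1)cn2[C@@H]1O[C@H](CO)[C@@H](O)[C@H]1O`). The difference is methylamino in place of methylsulfanyl on an aromatic carbon, with the rest of the molecule unchanged.

The measured data offer little guidance on this change. Among the measured compounds shown here, the only single-place step is a step that the limit leaves unreadable from compound 1 to compound 2, and it concerns a different group. Compound 2 and compound 3 differ in more than one place, so their gap cannot be assigned to any one change. For the measured compounds named here, no measured step involves methylsulfanyl or methylamino.

The expectation therefore starts from compound 3 at 450 nM, with a wide margin on both sides. The expected step in this assay is a 1.1-fold higher number from compound 3 to compound 4 (0.05 log units; within the scatter), with no shift beyond the scatter expected in either direction. Compound 4 is estimated at 500 nM, with an expected range from 80 nM to 3000 nM.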

Compound 4, half-maximal inhibitory concentration: > 20000 nM
Compound 4 gave a limit, no number; the forecaster's own chance of this, stated with the estimate: 8%; middle value at least 40-fold (1.60 log units) away from the limit.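

In this assay this aromatic carbon proves sensitive to what it carries, since methylamino in place of methylsulfanyl gives an at least 44-fold higher number from compound 3 to compound 4 (1.64 log units; beyond the scatter) with the rest of the molecule unchanged. Among the compounds shown here, this is the first readable single-place step, and it involves no change in heavy-atom count: a sulfur gives way to a nitrogen, and methylamino carries 1 hydrogen-bond donor where methylsulfanyl carries 0, though one pair cannot tell which of these differences matters. Compound 4 gives a limit and not a number, so the size of the step is bounded on one side only, and compound 4 now sits with compound 1 at that limit: the limit of > 20000 nM in this assay, at which 2 of the 4 values shown sit.

As far as these compounds go, what remains open is how narrow the tolerance at this carbon is, for instance whether a dimethylamino group, which has no hydrogen on its nitrogen, or a longer chain such as ethylsulfanyl would stay closer to compound 3 or fall with compound 4. Compound 1 and compound 2 carry methoxy at this carbon but differ from compound 3 in more than one place, so the effect of an oxygen link in this position also stays unsettled.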